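Pyrimidine hydrazide series: aryl swap at the shared core

The compounds below may be only part of what the source reports. "The series", "measured", "known", "first", "only" and "open" are said of these compounds alone.

Measured so far in a functional assay on Jurkat cells for inhibition of nuclear factor NF-kappa-B complex (Homo sapiens); on this read-out higher numbers stand for weaker inhibition and lower numbers for stronger inhibition:
compound 1 `CCOC(=O)c1cnc(-c2csc(C)n2)nc1NN1C(=O)C=C(C)C1=O` gives 8000 nM
compound 2 `CCOC(=O)c1cnc(-c2ccc(Cl)s2)nc1NN1C(=O)C=C(C)C1=O` gives 300 nM
compound 3 `CCOC(=O)c1cnc(CC2=CCCCC2)nc1NN1C(=O)C=C(C)C1=O` gives 2000 nM

Compound 1 stands highest of the three numbers in this assay. The nearest is compound 3, with a 4.0-fold lower number from compound 1 to compound 3 (0.60 log units; beyond the scatter); the furthest is compound 2, with a 27-fold lower number from compound 1 to compound 2 (1.43 log units; beyond the scatter). Between the other two, a 6.7-fold higher number from compound 2 to compound 3 (0.82 log units; beyond the scatter). Every change at this position of the shared core has so far moved the read-out beyond the scatter.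

Compound 4 `CCOC(=O)c1cnc(Oc2ccccc2)nc1NN1C(=O)C=C(C)C1=O` differs from compound 1 at the same place: phenoxy in place of 2-methyl-1,3-thiazol-4-yl on an aromatic carbon. The measured steps from compound 1 bear directly on it, since both replaced the 2-methyl-1,3-thiazol-4-yl group by something else on an aromatic carbon. The large step to compound 2 and the modest step to compound 3 both ran toward lower numbers. Phenoxy has not been tried here, and it carries an aromatic ring of carbon only, closer in kind to compound 2 than to compound 3 yet linked through oxygen; a step toward a lower number is therefore expected, of moderate size, in this assay.

The estimate for compound 4 is 1500 nM, range 400 nM to 6000 nM, which is expected to mean a 5.3-fold lower number from compound 1 to compound 4 (0.73 log units; beyond the scatter).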

Compound 4, half-maximal inhibitory concentration: 15000 nM
Compound 4: middle estimate off by 10-fold (1.00 log units), on the low side; measured number outside the range, above it.
By their numbers in this assay, from the lowest: compound 2; then compound 3; then compounds 1 and 4 (each within the scatter of the next).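

In this assay, for the compounds shown here, the change to phenoxy gives a 1.9-fold higher number from compound 1 to compound 4 (0.27 log units; within the scatter), the first change at this position of the shared core that stays within the scatter, so phenoxy and 2-methyl-1,3-thiazol-4-yl cannot be told apart on this read-out. An aromatic ring alone therefore does not bring the low number of compound 2: the series shows a 50-fold higher number from compound 2 to compound 4 (1.70 log units; beyond the scatter), and the non-aromatic (cyclohex-1-en-1-yl)methyl group of compound 3 also stands apart from phenoxy, with a 7.5-fold higher number from compound 3 to compound 4 (0.88 log units; beyond the scatter). The data at hand offer no explanation for these differences between groups.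

The compounds shown leave open whether the low number of compound 2 goes with the chlorine or with the thiophene ring, a question that plain thiophen-2-yl and a 5-chlorophenyl-type ring would address. They also leave open what the oxygen link of compound 4 contributes, which a phenyl group set directly on the aromatic carbon, or an anilino group with a nitrogen link, would help to separate from the ring itself.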